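Dropping a Methoxy Group in Two Related Series

This account rests on a few compounds, and the source may have more. Where it says the series, first, only, none or still open, it means among the compounds named here.

Compound 1, `COc1cccc(C(=O)/C=C/c2cc(Br)cc(OC)c2O)c1`, gives 47% in an ADME assay on MCF-10A cells (Homo sapiens) for cytotoxicity, read by sulforhodamine B assay, with a stated time of 72 h, tested at 30 uM; a higher number here means a stronger effect of the compound at the concentration tested, a lower number a weaker effect.
Compound 2, `COc1cccc(C(=O)/C=C/c2cc(Br)ccc2O)c1`, gives 66.3% in this assay.
Compound 3, `COc1cccc(C(=O)CC2C(C#N)=C(N)Oc3c(OC)cc(Br)cc32)c1`, gives 46.3% in this assay.

The first two compounds share one core and differ by a single change, (hydrogen in place of methoxy on an aromatic carbon). That change produced a number 19.3 percentage points higher from compound 1 to compound 2 (beyond the scatter). Compound 3 has a different core; how the core of compound 3 differs from the core of compound 1 is not broken down here. Its value is within the scatter of compound 1 and lies beyond the scatter below compound 2.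

Compound 4, `COc1cccc(C(=O)CC2C(C#N)=C(N)Oc3ccc(Br)cc32)c1`, is not yet measured. It differs from compound 3 by hydrogen in place of methoxy on an aromatic carbon. Among the measured compounds shown here, this is the same kind of change as the one from compound 1 to compound 2, though the surroundings differ: in compound 1 the methoxy group sits ortho to a hydroxy group and meta to a large group, whereas in compound 3 it sits ortho to a fused ring and meta to a fused ring; in both it is meta to a bromo group. Because a number 19.3 percentage points higher from compound 1 to compound 2 (beyond the scatter), a step of similar direction, a number 14.7 percentage points higher from compound 3 to compound 4 (beyond the scatter), is expected in this assay. Compound 4 is therefore estimated at 61%, most likely between 46% and 76%.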

Compound 4, a percentage reported as activity, at one concentration (the size of the read-out at that concentration, not a potency): 43.7%
The estimate for compound 4 lay 17.3 percentage points above the measured number; measured number outside the range, below it.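

In this assay, replacing the methoxy group with hydrogen on the core of compound 3 gave a number 2.6 percentage points lower from compound 3 to compound 4 (within the scatter), so on this core the two compounds cannot be told apart. The same replacement therefore did not carry over from one core to the other with the same result: the same change on two cores in this assay, a number 19.3 percentage points higher (beyond the scatter) from compound 1 to compound 2 and a number 2.6 percentage points lower (within the scatter) from compound 3 to compound 4, 21.9 percentage points apart, beyond the scatter of two such steps This shows that, for these two pairs, the outcome of the replacement depends on the core that carries it, but it does not show which part of the cores is responsible, and two pairs are too few to predict the outcome on any further core.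

The compounds shown have only methoxy or hydrogen at this place, so it remains open what an ethoxy group or an amine would do there on either core. Every compound shown also carries the bromo group, and how the replacement behaves without it is likewise open.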